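This account rests on a few compounds, and the source may have more. Where it says the series, first, only, none or still open, it means among the compounds named here.

Measured compounds:
- Compound 1, `c1ccc(-c2cnco2)c(NCC2=NCCN2)c1`: 20 nM
- Compound 2, `c1ccc(N2CCCCC2)c(NCC2=NCCN2)c1`: 12.6 nM
- Compound 3, `Oc1ccc2cccc(NCC3=NCCN3)c2c1`: 6.31 nM

In a functional assay for activation of Alpha-1A adrenergic receptor (Homo sapiens) (on this read-out higher numbers stand for an effect only at larger amounts of compound and lower numbers for an effect already at smaller amounts), compound 3 gives the lowest number of the three. Compound 2 sits closest to it, within the scatter, while compound 1 lies furthest away, beyond the scatter. Going by the values given here, the one step measured between compounds that differ in a single place is a 1.6-fold lower number from compound 1 to compound 2 (0.20 log units; within the scatter), a change made on an aromatic carbon.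

Compound 4, `Oc1ccc2cccc(NCc3c[nH]cn3)c2c1`, has not been measured. It differs from compound 3 in this way: a group of 5 heavy atoms (3 carbon, 2 nitrogen; one five-membered aromatic ring with 2 hetero atoms) in place of a group of 5 heavy atoms (3 carbon, 2 nitrogen; one five-membered non-aromatic ring with 2 hetero atoms), on a saturated chain carbon bound to a nitrogen on an aromatic ring. Among the compounds with values here, no measured step touches this part of the molecule; the step from compound 1 to compound 2 concerns a group on an aromatic carbon and says nothing about the group bound to the chain carbon. The expectation therefore rests on the value of compound 3 alone, with wide uncertainty. Compound 4 is expected to give 40 nM in this assay, with a range of 8 nM to 250 nM. This estimate means a step of a 6.3-fold higher number from compound 3 to compound 4 (0.80 log units; beyond the scatter), which is expected rather than known.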

Compound 4, half-maximal effective concentration: 63.1 nM
Compound 4: the middle estimate sits 1.6-fold (0.20 log units) below what was measured; the measured number falls inside the stated range.
By their numbers in this assay, from the lowest: compounds 3, 2 and 1 (each within the scatter of the next, the first and the last beyond it); then compound 4.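

Placed on the saturated chain carbon bound to a nitrogen on an aromatic ring, 1H-imidazol-4-yl in place of the non-aromatic ring gives a 10-fold higher number from compound 3 to compound 4 (1.00 log units; beyond the scatter) in this assay, the first measured sign that this position responds to a change of group. The two groups have the same count of heavy atoms and both are five-membered rings, so in this pair the number moves beyond the scatter without any change in group size or ring size. Nothing measured here explains the shift, and no supporting data bear on it.

The compounds shown leave open whether the same exchange would have a similar effect on the cores of compound 1 and compound 2. They also leave open how a pyridin-2-yl ring or an open-chain amidine would behave at this place.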